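Anilinopyrimidine series: aryl variation and cell tolerance

The source may hold more compounds than are shown below. What is called first, only, known or untested is meant among the compounds shown, and "the series" means these compounds.

Measured compounds in an ADME assay on MT4 cells (Homo sapiens) for cytotoxicity, read by MTT assay, with a stated time of 4 days; a higher number here means that more compound is tolerated, a lower number that less compound is tolerated:
compound 1, `COc1ccc(-c2cc(C)c(Nc3ccnc(Nc4ccc(C#N)cc4)n3)c(C)c2)cc1`, gives 2890 nM
compound 2, `Cc1cc(-c2ccccc2C(F)(F)F)cc(C)c1Nc1ccnc(Nc2ccc(C#N)cc2)n1`, gives 4210 nM
compound 3, `Cc1cc(-c2cc(Cl)cc(Cl)c2)cc(C)c1Nc1ccnc(Nc2ccc(C#N)cc2)n1`, gives 4290 nM

Compound 2 stands second highest of the three numbers; its nearest neighbour is compound 3 at a 1.0-fold higher number from compound 2 to compound 3 (0.01 log units; within the scatter), and its furthest is compound 1 at a 1.5-fold higher number from compound 1 to compound 2 (0.16 log units; within the scatter). All three values lie within the scatter of one another, so no ordering among them can be claimed.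

Compound 4, `Cc1cccc(-c2cc(C)c(Nc3ccnc(Nc4ccc(C#N)cc4)n3)c(C)c2)c1`, is unmeasured. It differs from compound 2 by 3-methylphenyl in place of 2-(trifluoromethyl)phenyl on an aromatic carbon.

For the measured compounds named here, the steps that bear on this change are those that swap the same aryl group on compound 2: a 1.5-fold higher number from compound 1 to compound 2 (0.16 log units; within the scatter) and a 1.0-fold higher number from compound 2 to compound 3 (0.01 log units; within the scatter). Both were within the scatter, and the three aryl groups seen so far gave no change beyond it. For compound 4 the expected step is therefore a 1.1-fold lower number from compound 2 to compound 4 (0.03 log units; within the scatter), which is none beyond the scatter. Compound 4 is estimated at 3900 nM, with a range from 2000 nM to 7800 nM.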

Compound 4, half-maximal cytotoxic concentration: 3670 nM
Compound 4: the middle estimate sits 1.1-fold (0.03 log units) above what was measured; low and high end bracket the measured number.
By their numbers in this assay, from the lowest: compounds 1, 4, 2 and 3 (each within the scatter of the next).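

In this assay, 3-methylphenyl, an aryl group of carbon only, joins the three earlier aryl groups at this position with no step beyond the scatter (a 1.1-fold lower number from compound 2 to compound 4 (0.06 log units; within the scatter); a 1.2-fold lower number from compound 3 to compound 4 (0.07 log units; within the scatter); a 1.3-fold higher number from compound 1 to compound 4 (0.10 log units; within the scatter)). The earlier groups all carried fluorine, chlorine or oxygen, so compound 4 shows that the number stays within the scatter with none of these atoms on the aryl group. Nothing measured here accounts for this flat reading.

From the compounds shown here alone, what remains open is whether a non-aryl group at this position, such as a longer alkyl chain, or a phenyl ring bearing an amine or a carboxylic acid, would give a step beyond the scatter. The four compounds shown define no lower or upper edge for this position, since all their aryl groups sit within the scatter of one another.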